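Iodine to Bromine and Tolerance in Liver Cells

This account rests on a few compounds, and the source may have more. Where it says the series, first, only, none or still open, it means among the compounds named here.

Compound 1 `O=C1C2C=C(I)C(CC2OCCCCCCO)[C@]12CO2` and compound 3 `O=C1C2C=C(Br)C(CC2OCCCCCCO)[C@]12CO2` share one core, while compound 2 `O=C1[C@@]2(CO)C=C(I)C(CC2c2ccccc2)[C@]12CO2` and compound 4 `O=C1[C@@]2(CO)C=C(Br)C(CC2c2ccccc2)[C@]12CO2` share another; how the two cores differ is not broken down here. In an ADME assay on Huh-7 cells (Homo sapiens) for cytotoxicity (a higher number here means that more compound is tolerated, a lower number that less compound is tolerated), compound 1 gives > 50000 nM, which is a limit of the assay rather than a number. Compound 3 likewise gives > 50000 nM in this assay, again a limit. The change between these two is bromo in place of iodo on a double-bonded ring carbon and its size is a step that the two limits leave unreadable from compound 1 to compound 3, because the limit of > 50000 nM in this assay, at which 2 of the 3 values shown sit, hides whatever movement there was. Compound 2 is the only one of the three measured compounds with a number, giving 27100 nM in this assay. Compound 4 differs from compound 2 by bromo in place of iodo on a double-bonded ring carbon, the same kind of change, though here the place is also two ring bonds from the ring atom that bears a hydroxymethyl group (2 heavy atoms). Since the earlier step stands only as a step that the two limits leave unreadable from compound 1 to compound 3, compound 4 is expected to show a 1.1-fold higher number from compound 2 to compound 4 (0.04 log units; within the scatter), a small step. Compound 4 is therefore estimated at 30000 nM, with a range from 12000 nM to 60000 nM.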

Compound 4, half-maximal cytotoxic concentration: > 50000 nM
Compound 4 ended at the assay's limit; the forecaster's own chance of this, stated with the estimate: 25%; at least 1.6-fold (0.22 log units) between middle value and limit.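

In this assay compound 4 gives > 50000 nM, which is a limit of the assay and not a number. Going by these compounds, on the core of compound 2, bromo in place of iodo on a double-bonded ring carbon therefore gives an at least 1.8-fold higher number from compound 2 to compound 4 (0.26 log units; that floor lies within the scatter); this is only a floor, so the true size of the step stays unknown, and the data do not establish a real change. The same change on the core of compound 1 cannot be read, so the two cores cannot be compared, and nothing shows whether the change carries from one core to the other with the same size, because the readings stop at one limit: the limit of > 50000 nM in this assay, at which 3 of the 4 values shown sit.

The compounds shown leave open how large the step from iodo to bromo would be on either core if both partners gave numbers rather than limits. Also open, on these data alone, is how a different group at that double-bonded ring carbon, such as chloro or an amine, would read in this assay.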